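Removing the nitrogen carbonate from a carbapenem prodrug

The source may report more compounds than this note shows. Statements on the series, on what has been measured and on what is new or still open speak of the compounds shown alone.

Compound 1 `CCOC(=O)C1=C(S[C@@H]2CN[C@H](C(=O)Nc3cccc(C(=O)OCC)c3)C2)[C@H](C)[C@@H]2[C@@H]([C@@H](C)OC(C)=O)C(=O)N12`: < 57.4 ng.h/mL
Compound 2 `CCOC(=O)C1=C(S[C@@H]2CN[C@H](C(=O)Nc3cccc(C(=O)OCC)c3)C2)[C@H](C)[C@@H]2[C@@H]([C@@H](C)OC(=O)[C@@H](N)C(C)C)C(=O)N12`: "below limit of detection" (no number reported)
Compound 3 `CCOC(=O)C1=C(S[C@H]2C[C@@H](C(=O)Nc3cccc(C(=O)OCC)c3)N(C(=O)OCc3oc(=O)oc3C)C2)[C@H](C)[C@@H]2[C@@H]([C@@H](C)O)C(=O)N12`: "below limit of detection" (no number reported)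

In an ADME assay on the whole organism (plasma, strain Beagle) for pharmacokinetics, with Canis familiaris (Canis lupus familiaris) as the target, read by LC-MS, with a stated time of 8 h, at a dose of 10 mg/kg by the intraduodenal route (on this read-out higher numbers stand for higher exposure at the dose given and lower numbers for lower exposure), compound 1 reaches only a limit of the assay, < 57.4 ng.h/mL. Compound 2 gives "below limit of detection" (no number reported) in this assay. Compound 3 likewise gives "below limit of detection" (no number reported), so it stands without a number of its own, in the same position as compound 2. Compound 1 also rests at a limit (the limit of < 57.4 ng.h/mL in this assay, at which 1 of the 3 values shown sits), so none of the three offers a measured exposure. Compound 4 `CCOC(=O)C1=C(S[C@@H]2CN[C@H](C(=O)Nc3cccc(C(=O)OCC)c3)C2)[C@H](C)[C@@H]2[C@@H]([C@@H](C)O)C(=O)N12` differs from compound 3 by a hydrogen atom in place of a group of 11 heavy atoms (6 carbon, 5 oxygen; one five-membered aromatic ring with 2 hetero atoms), on an amine nitrogen in a ring, leaving the ring amine unsubstituted. Within the data shown here, no measured step exists between these two; with every measured compound at or under a limit, no direction beyond the scatter can be drawn. A low exposure is expected for compound 4 as well, estimated at 40 ng.h/mL, between 5 ng.h/mL and 250 ng.h/mL.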

Compound 4, area under the concentration-time curve: 2660 ng.h/mL
Compound 4: middle estimate off by 67-fold (1.82 log units), on the low side, outside the stated range (above it).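

Among these compounds, compound 4 is the only compound here with a number of its own in this assay, and the change on the oxygen on a saturated carbon gives an at least 46-fold higher number from compound 1 to compound 4 (1.66 log units; beyond the scatter) with the ring amine unsubstituted on both sides. This position therefore matters on its own: the free hydroxyl of compound 4 gives a measured exposure, which the acetyl of compound 1 does not. The value of compound 1 is a limit of the assay: the limit of < 57.4 ng.h/mL in this assay, at which 1 of the 4 values shown sits.

Still open, from the compounds shown here alone, is how a longer acyl chain on this oxygen would read. So is whether a carboxylic acid in place of either ethyl ester would keep a measurable exposure.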